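The source may hold more compounds than are shown below. What is called first, only, known or untested is meant among the compounds shown, and "the series" means these compounds.

Compound 3 `C=CCc1cc(C(C)=O)c(O)cc1OCCCCCCC#N` gives 63% in an assay on isolated protein for binding affinity to leukotriene B4 receptor 1 (Homo sapiens), tested at 1 uM (on this read-out higher numbers stand for more inhibition at the one concentration tested (going by the name of the read-out) and lower numbers for less inhibition), and stands second highest of the three measured numbers. Compound 1 `CCc1cc(C(C)=O)c(O)cc1OCCCCCCC#N` gives 73% in this assay, a gap within the scatter (a number 10 percentage points lower from compound 1 to compound 3 (within the scatter)), whereas compound 2 `COCc1cc(C(C)=O)c(O)cc1OCCCCCCC#N` gives 7%, well apart (a number 56 percentage points higher from compound 2 to compound 3 (beyond the scatter)). Compound 4 `C=CCc1cc(C(C)=O)c(O)cc1OCCCC` keeps the shared core; the change is hydrogen in place of 2-cyanoethyl on a saturated chain carbon, four bonds along the chain from an oxygen on an aromatic ring. Within the data shown here, no measured step touches this place: a number 66 percentage points lower from compound 1 to compound 2 (beyond the scatter), a number 10 percentage points lower from compound 1 to compound 3 (within the scatter) and a number 56 percentage points higher from compound 2 to compound 3 (beyond the scatter) all vary the group on the saturated chain carbon bound to an aromatic carbon, and the chain ending in the nitrile is the same in all three. The size and direction of the step are thus not fixed by any measured pair. Compound 4 is estimated at 35%, with a range of 5% to 70%. This means an expected step of a number 28 percentage points lower from compound 3 to compound 4 (beyond the scatter).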

Compound 4, a percentage reported as inhibition, at one concentration (the size of the read-out at that concentration, not a potency): 8%
For compound 4 the middle estimate is 27 percentage points above the measured one; the range from low to high includes it.
By their numbers in this assay, from the lowest: compounds 2 and 4 (each within the scatter of the next); then compounds 3 and 1 (each within the scatter of the next).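

Hydrogen in place of 2-cyanoethyl, four bonds along the chain from an oxygen on an aromatic ring, gives a number 55 percentage points lower from compound 3 to compound 4 (beyond the scatter) in this assay. Among these compounds, this place, identical in the earlier compounds, therefore also governs the read-out, not only the group on the saturated chain carbon bound to an aromatic carbon. No measurement at hand gives a reason for this step.

The change removes the nitrile and the chain carbons together, so their shares stay unseparated. A chain ending in an amine or a carboxylic acid, or a plain longer chain, would tell them apart.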